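The source may report more compounds than this note shows. Statements on the series, on what has been measured and on what is new or still open speak of the compounds shown alone.

Measured so far:
compound 1 `CC(C)(O)C#Cc1cc(C(O)(C(F)(F)F)C(F)(F)F)cnc1N1CCN(S(=O)(=O)c2ccc(N)nc2)CC1`, in an ADME assay (liver) for metabolic stability, with Liver microsome (Homo sapiens) as the target, using microsomes and NADPH, with a stated time of 30 min, tested at 1 uM (on this read-out lower numbers stand for slow clearance and higher numbers for fast clearance), compound 1 gives < 14 mL.min-1.g-1; this is a limit of the assay, not a number.
compound 2 `Cn1cc(-c2cc(C(O)(C(F)(F)F)C(F)(F)F)cnc2N2CCN(S(=O)(=O)c3ccc(N)nc3)CC2)cn1`, in this assay compound 2 gives 19 mL.min-1.g-1.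
compound 3 `Nc1ccc(S(=O)(=O)N2CCN(c3ncc(C(O)(C(F)(F)F)C(F)(F)F)cc3-c3ccccc3O)CC2)cn1`, in this assay compound 3 gives 22 mL.min-1.g-1.

Compound 1 therefore stands only at a limit in this assay, (the limit of < 14 mL.min-1.g-1 in this assay, at which 1 of the 3 values shown sits). Compound 4 `CS(=O)(=O)Nc1cccc(-c2cc(C(O)(C(F)(F)F)C(F)(F)F)cnc2N2CCN(S(=O)(=O)c3ccc(N)nc3)CC2)c1` is not yet measured. The change from compound 1 to compound 4 is 3-(methanesulfonamido)phenyl in place of 3-hydroxy-3-methylbut-1-yn-1-yl on an aromatic carbon. Both measured steps that start from compound 1 replace the 3-hydroxy-3-methylbut-1-yn-1-yl group with a ring: an at least 1.3-fold higher number from compound 1 to compound 2 (0.13 log units; that floor lies within the scatter), an at least 1.5-fold higher number from compound 1 to compound 3 (0.19 log units; that floor lies within the scatter); and between the two ring-bearing compounds a 1.2-fold higher number from compound 2 to compound 3 (0.06 log units; within the scatter). The change to compound 4 likewise brings in a six-membered aromatic ring of carbon only, so a step of the same modest size, upward and within the scatter, is expected: an at least 1.4-fold higher number from compound 1 to compound 4 (0.15 log units; that floor lies within the scatter). Compound 4 is estimated at 20 mL.min-1.g-1 in this assay, expected to lie between 10 mL.min-1.g-1 and 40 mL.min-1.g-1.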

Compound 4, intrinsic clearance in microsomes: 40 mL.min-1.g-1
Compound 4: the middle estimate sits 2.0-fold (0.30 log units) below what was measured, within the range that was stated.
By their numbers in this assay, from the lowest: compounds 2, 3 and 4 (each within the scatter of the next, the first and the last beyond it). At a limit, below all of these: compound 1.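

In this assay, this position, ortho to a large group, now gives steps beyond the scatter, which the earlier ring-for-alkynyl changes did not: an at least 2.8-fold higher number from compound 1 to compound 4 (0.45 log units; beyond the scatter), and a 2.1-fold higher number from compound 2 to compound 4 (0.32 log units; beyond the scatter). The 3-(methanesulfonamido)phenyl group is separated from the 1-methyl-1H-pyrazol-4-yl group but not from the 2-hydroxyphenyl group: a 1.8-fold higher number from compound 3 to compound 4 (0.26 log units; within the scatter). Compound 1 stands at a limit of the assay, not a number, so the step that starts from it is a floor: the limit of < 14 mL.min-1.g-1 in this assay, at which 1 of the 4 values shown sits.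

The compounds shown do not tell whether the step follows the methanesulfonamido group or the phenyl ring that carries it. Also open, on these data alone, is how an amine or a carboxylic acid in place of the methanesulfonamido group on that phenyl ring would read in this assay.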